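Swapping a pyridine for a pyrazole on a shared core

The source may report more compounds than this note shows. Statements on the series, on what has been measured and on what is new or still open speak of the compounds shown alone.

Measured compounds and their values in an ADME assay on microsomes from liver (Homo sapiens) for metabolic stability, read by LC-MS, using NADPH, with stated times of 5 min and 30 min, tested at 1 uM; on this read-out higher numbers stand for fast clearance and lower numbers for slow clearance:
compound 1, `Cc1nc(CO)ccc1-c1cnc(NCc2c(F)ccc3c2CCO3)c2cn[nH]c(=O)c12`: 11 mL.min-1.g-1
compound 2, `COCCC(=O)Nc1cnc(NCc2c(F)ccc3c2CCO3)n2cnnc12`: < 3 mL.min-1.g-1
compound 3, `CN(C)Cc1ccc2c(c1)CN(c1cnc(NCc3c(F)ccc4c3CCO4)n3cnnc13)C2=O`: 19 mL.min-1.g-1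

Of the compounds shown here, three have been tested so far. Compound 1 has the lower of the two numbers given, while compound 3 sits a little higher, a difference that is within the usual scatter of this kind of measurement, so no order between compound 1 and compound 3 can be claimed. For compound 2, this assay reports < 3 mL.min-1.g-1, which is a limit of the assay rather than a number, and (the limit of < 3 mL.min-1.g-1 in this assay, at which 1 of the 3 values shown sits).

Compound 4, `Cc1nn(C)cc1-c1cnc(NCc2c(F)ccc3c2CCO3)c2cn[nH]c(=O)c12`, has not yet been measured. It differs from compound 1 in one place: 1,3-dimethyl-1H-pyrazol-4-yl in place of 6-(hydroxymethyl)-2-methylpyridin-3-yl on an aromatic carbon. The 6-(hydroxymethyl)-2-methylpyridin-3-yl group leaves and the 1,3-dimethyl-1H-pyrazol-4-yl group enters on the same aromatic carbon of the shared core.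

Going by the values given here, no measured pair with a change of this kind is available, so the size of the step can only be estimated. The expectation is a step that stays within the scatter, with at most a modest rise in clearance; the estimated step is a 1.3-fold higher number from compound 1 to compound 4 (0.10 log units; within the scatter). Compound 4 is therefore expected to give about 14 mL.min-1.g-1 in this assay, with a likely range from 6 mL.min-1.g-1 to 35 mL.min-1.g-1.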

Compound 4, intrinsic clearance in microsomes: 27 mL.min-1.g-1
The estimate for compound 4 lay 1.9-fold (0.29 log units) below the measured number; the measured number falls inside the stated range.
By their numbers in this assay, from the lowest: compounds 1, 3 and 4 (each within the scatter of the next, the first and the last beyond it). At a limit, below all of these: compound 2.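

In this assay, going by these compounds alone, this aromatic carbon, para to a large group on the shared core, proves sensitive to the group it carries: 1,3-dimethyl-1H-pyrazol-4-yl in place of 6-(hydroxymethyl)-2-methylpyridin-3-yl gives a 2.5-fold higher number from compound 1 to compound 4 (0.39 log units; beyond the scatter) and this is the only step that can be read in the set. The step is modest but lies beyond the scatter, so the two groups are not interchangeable here, although both are aromatic rings with no net charge. Nothing measured on these compounds bears on the cause of this rise, and the loss of the hydrogen-bond donor, the change from a six-membered to a five-membered ring and the change in ring hetero atoms cannot be told apart.

Open, on these data alone, is which of these differences carries the step, for instance whether a pyrazole bearing a hydroxymethyl group would stay closer to compound 1 than to compound 4. Also open, as far as these compounds go, is how an amine or a carboxylic acid on the ring at this position would read on this scale.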